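This account rests on a few compounds, and the source may have more. Where it says the series, first, only, none or still open, it means among the compounds named here.

Measured so far in an ADME assay on microsomes from liver (Rattus norvegicus) for metabolic stability, tested at 2.5 uM; a higher number here means faster removal of the compound, a lower number slower removal:
compound 1 `O=S(=O)(c1ccc(F)cc1)c1cnc2cc(Cl)c(F)cc2c1-c1ccc(Cl)cc1` gives 0.57 mL/min
compound 2 `O=S(=O)(c1ccc(F)cc1)c1cnc2ccc(Cl)cc2c1-c1ccc(Cl)cc1` gives 0.2 mL/min
compound 3 `O=S(=O)(c1ccc(F)cc1)c1cnc2cc(Cl)ccc2c1-c1ccc(Cl)cc1` gives 0.01 mL/min

Compound 1 and compound 3 differ by fluoro in place of hydrogen on an aromatic carbon; this change gave a 57-fold higher number from compound 3 to compound 1 (1.76 log units; beyond the scatter). The difference between the cores of compound 2 and compound 3 is not broken down here. Compound 4 `O=S(=O)(c1ccc(F)cc1)c1cnc2c(F)cc(Cl)cc2c1-c1ccc(Cl)cc1`, not yet measured in this assay, differs from compound 2 by fluoro in place of hydrogen on an aromatic carbon. This is the same kind of change as from compound 3 to compound 1, but the surroundings differ: the entering fluoro in compound 4 sits ortho to a fused ring and meta to a chloro group, whereas in compound 1 it sits ortho to a chloro group and para to a fused ring. Resting on the single precedent, compound 4 is expected to show a 4.0-fold higher number from compound 2 to compound 4 (0.60 log units; beyond the scatter), a smaller step than the earlier one. Compound 4 is estimated at 0.8 mL/min, between 0.2 mL/min and 3 mL/min.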

Compound 4, intrinsic clearance in a liver preparation (reported as CLH), per the amount of preparation that the assay uses: 0.09 mL/min
Estimate against measurement, compound 4: 8.9-fold (0.95 log units) above, outside the stated range (below it).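

In this assay, fluoro in place of hydrogen on an aromatic carbon gave a 2.2-fold lower number from compound 2 to compound 4 (0.35 log units; beyond the scatter), opposite in direction to a 57-fold higher number from compound 3 to compound 1 (1.76 log units; beyond the scatter). Neither the size nor the direction of this change carries from one core to the other here, and the two steps clearly differ: the same change on two cores in this assay, a 57-fold higher number (1.76 log units; beyond the scatter) from compound 3 to compound 1 and a 2.2-fold lower number (0.35 log units; beyond the scatter) from compound 2 to compound 4, 130-fold (2.10 log units) apart, beyond the scatter of two such steps

Among these compounds, only one pair per core is at hand and the entering fluoro stands in a different place in each, so the data do not separate the effect of the core from that of the place, and say nothing about a third core. Still open, from the compounds shown here alone, is how a methoxy group or a nitrile would behave on the carbon that carries fluoro in compound 4. Also open, going by these compounds, is whether an amine in place of the chloro group would change the picture in this assay.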